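This account rests on a few compounds, and the source may have more. Where it says the series, first, only, none or still open, it means among the compounds named here.

Measured compounds:
compound 1, `COc1ccc(-c2[nH]c3ccccc3c2/C=C(\C#N)S(=O)(=O)c2ccccc2)cc1`: 535 nM
compound 2, `O=C(/C(=C\c1c(-c2ccccc2)[nH]c2ccccc12)S(=O)(=O)c1ccccc1)c1ccccc1`: 6500 nM

Both were tested in a functional assay on K562 cells (Homo sapiens) for inhibition, read by sulforhodamine B assay, with a stated time of 48 h; a higher number here means a weaker inhibitor of growth, a lower number a stronger inhibitor of growth. Compound 2 has the higher number of the two, and the gap to compound 1 lies beyond the usual scatter. Compound 3, `N#C/C(=C\c1c(-c2ccccc2)[nH]c2ccccc12)S(=O)(=O)c1ccccc1`, has not yet been measured. It differs from compound 2 in one place: cyano in place of benzoyl on a double-bonded chain carbon bound to a double-bonded chain carbon and a sulfonyl sulfur. Compound 3 thus carries the same cyano as compound 1, which in this assay gives 535 nM. A move toward that value is expected, so the step of an 8.1-fold lower number from compound 2 to compound 3 (0.91 log units; beyond the scatter) is estimated as a clear drop. Compound 3 is expected near 800 nM, within 250 nM to 2500 nM.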

Compound 3, concentration for 50% growth inhibition: 348 nM
Compound 3: middle estimate off by 2.3-fold (0.36 log units), on the high side; the measured number falls inside the stated range.
By their numbers in this assay, from the lowest: compounds 3 and 1 (each within the scatter of the next); then compound 2.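

In this assay the swap of benzoyl for cyano on this chain carbon now stands alone as a single change and is large (a 19-fold lower number from compound 2 to compound 3 (1.27 log units; beyond the scatter)), which compounds 1 and 2 could not show because they differ in more than one place. Hydrogen in place of methoxy on an aromatic carbon stays within the scatter (a 1.5-fold lower number from compound 1 to compound 3 (0.19 log units; within the scatter)), so the methoxy makes no measurable difference here. No measured data explain either result. Still open, from the compounds shown here alone, is whether a carboxylic acid or an amide on this chain carbon would match cyano, and whether an amine on the aromatic carbon would alter growth inhibition.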